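The source may report more compounds than this note shows. Statements on the series, on what has been measured and on what is new or still open speak of the compounds shown alone.

In a functional assay on MT4 cells (Homo sapiens), read by MTT assay (a higher number here means that more compound is tolerated, a lower number that less compound is tolerated), compound 1 `C#C[C@]1(CO)O[C@@H](n2cc(Cl)c(=O)[nH]c2=O)C[C@@H]1O` gives a half-maximal cytotoxic concentration of 81700 nM. Compound 2 `C#C[C@]1(CO)O[C@@H](n2cc(Br)c(=O)[nH]c2=O)C[C@@H]1O` has no number in this assay, only a limit of > 100000 nM. Where compound 2 stands is therefore known only from the limit of > 100000 nM in this assay, at which 1 of the 2 values shown sits.

Compound 3 `C#C[C@]1(CO)O[C@@H](n2cc(I)c(=O)[nH]c2=O)C[C@@H]1O` differs from compound 2 by one further exchange on the shared core, iodo in place of bromo on an aromatic carbon. Within the data shown here, the one measured step that bears on this is the preceding exchange, bromo in place of chloro on an aromatic carbon, which gave an at least 1.2-fold higher number from compound 1 to compound 2 (0.08 log units; that floor lies within the scatter). That figure is only a floor and lies within the scatter, so it fixes neither a size nor a firm direction. With that single step as the guide, no change beyond the scatter is expected in this assay, and another report as a limit is quite possible. The expected step is a number no higher from compound 2 to compound 3 (the limit leaves the size open). For compound 3 the estimated value is 100000 nM, with an expected range from 45000 nM to 200000 nM.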

Compound 3, half-maximal cytotoxic concentration: > 260000 nM
Compound 3: a limit, no number; the forecaster's own chance of this, stated with the estimate: 65%; middle value at least 2.6-fold (0.41 log units) from the limit.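

In this assay compound 3, the iodo member of the series, has only a limit of > 260000 nM and no number. Exchanging chloro for iodo on this aromatic carbon gives an at least 3.1-fold higher number from compound 1 to compound 3 (0.50 log units; beyond the scatter) and so shows what the chloro-to-bromo exchange alone could not: a change of halogen at this position, ortho to a group of 1 heavy atom and meta to a large group, can raise the tolerated concentration by more than the scatter of the assay. From the compounds shown here alone, the step from compound 2 to compound 3 cannot be read, as both values are limits, so whether iodo differs from bromo here remains unknown.

Going by these compounds, how far the true values of compound 2 and compound 3 lie beyond their limits stays open, and with it the size of the exchange from chloro to iodo and any order between bromo and iodo. Also open is how this assay would respond at this carbon to fluoro, a methyl group, an amine or a nitrile, none of which stands among the three compounds shown here.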